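Shortening the Butyl Chain on a Whole-Animal Activation Read-out

This account rests on a few compounds, and the source may have more. Where it says the series, first, only, none or still open, it means among the compounds named here.

For the measured compounds named here, compound 2 `CCCCc1nc(N)c2nc(O)n(Cc3ccccc3)c2n1` is one of two compounds measured in a functional assay on the whole organism for activation, with Mus musculus as the target (on this read-out lower numbers stand for an effect already at smaller amounts and higher numbers for an effect only at larger amounts of compound), where compound 2 gives 0.3 mg/kg. Going by the values given here, its only neighbour, compound 1 `CCCSc1nc(N)c2nc(O)n(Cc3ccccc3)c2n1`, gives 0.1 mg/kg, and the step between them, a 3.0-fold higher number from compound 1 to compound 2 (0.48 log units; beyond the scatter), comes from a butyl in place of a propylsulfanyl on an aromatic carbon. So compound 2 stands at the higher of the two numbers, its partner lying beyond the scatter below it.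

Compound 3 `CCCc1nc(N)c2nc(O)n(Cc3ccccc3)c2n1` is not yet measured. It differs from compound 2 by hydrogen in place of methyl on a saturated chain carbon, three bonds along the chain from an aromatic carbon, so the butyl of compound 2 is cut back to a propyl while everything else stays the same. Among the compounds with values here, no measured step deals with such a shortening of a chain: the one step known, a 3.0-fold higher number from compound 1 to compound 2 (0.48 log units; beyond the scatter), exchanges a sulfur-containing group for a carbon chain of the same length and says little about one carbon more or less. With no direct guide, a step within the scatter is expected, written as no change at the digits printed from compound 2 to compound 3 (within the scatter). Compound 3 is therefore estimated to give 0.3 mg/kg in this assay, with a range from 0.1 mg/kg to 1 mg/kg.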

Compound 3, minimum effective dose: 3 mg/kg
Estimate against measurement, compound 3: 10-fold (1.00 log units) below; the whole stated range lies below it.
By their numbers in this assay, from the lowest: compound 1; then compound 2; then compound 3.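

In this assay, for the compounds shown here, cutting butyl back to propyl is far from a neutral edit: it gives a 10-fold higher number from compound 2 to compound 3 (1.00 log units; beyond the scatter) and so the end of this chain counts for more than the earlier compounds could show, a larger step than a 3.0-fold higher number from compound 1 to compound 2 (0.48 log units; beyond the scatter) seen on exchanging propylsulfanyl for butyl. Propyl in place of propylsulfanyl gives a 30-fold higher number from compound 1 to compound 3 (1.48 log units; beyond the scatter) as the largest step in this set, so two groups that might look alike on paper are far from interchangeable at this aromatic carbon, and the butyl of compound 2 sits between them on this read-out. Nothing available explains why these steps are so large.

As far as these compounds go, whether a longer chain such as pentyl would bring the number down further, or whether the trend from propyl to butyl stops there, stays open. So does the result for a butylsulfanyl group, or for a propoxy group with oxygen in the place of the sulfur, which would show how far the linking atom itself matters apart from chain length.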